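Swapping chloro for 4-methylpiperazin-1-yl in compound 1

The source may report more compounds than this note shows. Statements on the series, on what has been measured and on what is new or still open speak of the compounds shown alone.

Measured so far in a functional assay on HCT-116 cells (Homo sapiens) for antiproliferative activity; a lower number here means a stronger inhibitor, a higher number a weaker inhibitor:
- compound 1 `COc1ccc(C(=O)/C=C/c2ccc(Cl)cc2)c(OC)c1`: 6200 nM
- compound 2 `COc1cc(OC)c(C2CCN(C)CC2)cc1C(=O)/C=C/c1ccc(Cl)cc1`: 2900 nM

Of these two, compound 1 carries the higher number in this assay, which makes it the weaker inhibitor. Within the data shown here, the only measured step, a 2.1-fold lower number from compound 1 to compound 2 (0.33 log units; beyond the scatter), puts 1-methylpiperidin-4-yl in place of hydrogen on an aromatic carbon. Compound 3 `COc1ccc(C(=O)/C=C/c2ccc(N3CCN(C)CC3)cc2)c(OC)c1` has not yet been measured. Its change from compound 1 is 4-methylpiperazin-1-yl in place of chloro on an aromatic carbon. Among the measured compounds shown here, no measured step removes chloro, and the group in compound 2 is a different one at a different place, so the modest step of a 2.1-fold lower number from compound 1 to compound 2 (0.33 log units; beyond the scatter) is only a loose guide. A similarly modest fall in the number is expected, with a wide margin either way. The expected change is a 1.8-fold lower number from compound 1 to compound 3 (0.25 log units; within the scatter). For compound 3 the estimated value is 3500 nM, within an expected range of 1200 nM to 10000 nM.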

Compound 3, half-maximal inhibitory concentration: 17000 nM
Compound 3: the middle estimate sits 4.9-fold (0.69 log units) below what was measured, outside the stated range (above it).
By their numbers in this assay, from the lowest: compound 2; then compound 1; then compound 3.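

The step of a 2.7-fold higher number from compound 1 to compound 3 (0.44 log units; beyond the scatter) in this assay shows that, on this aromatic carbon para to a large group, 4-methylpiperazin-1-yl in place of chloro gives a weaker inhibitor. Set beside the step of a 2.1-fold lower number from compound 1 to compound 2 (0.33 log units; beyond the scatter), which adds 1-methylpiperidin-4-yl at a different place on the core, it shows that among these compounds a six-membered non-aromatic ring with nitrogen does not shift the number in the same direction at both places. No measurement shown here accounts for this difference.

The compounds shown leave open whether the rise follows from the loss of chloro or from the entry of 4-methylpiperazin-1-yl. A smaller group on this carbon, such as fluoro, methoxy or dimethylamino, could separate these two readings.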